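Methylation of one catechol oxygen in a glycosylated diarylheptanoid pair

The compounds below may be only part of what the source reports. "The series", "measured", "known", "first", "only" and "open" are said of these compounds alone.

Measured compounds:
compound 1, `COc1cc(CC[C@H](C[C@H](O)CCc2ccc(O)cc2)O[C@@H]2O[C@H](CO)[C@@H](O)[C@H](O)[C@H]2O)ccc1O`: > 10 ug/mL
compound 2, `OC[C@H]1O[C@@H](O[C@H](CCc2ccc(O)c(O)c2)C[C@H](O)CCc2ccc(O)c(O)c2)[C@H](O)[C@@H](O)[C@@H]1O`: 3 ug/mL

Going by the values given here, in a functional assay on HL-60 cells (Homo sapiens) for cytotoxicity, read by MTT assay, with a stated time of 72 h (a higher number here means a weaker inhibitor, a lower number a stronger inhibitor), compound 2 gives 3 ug/mL, the only numerical value in the set. For compound 1 the result > 10 ug/mL is a limit of the assay, not a number; this is the situation described by the limit of > 10 ug/mL in this assay, at which 1 of the 2 values shown sits. Nothing more can be drawn from the pair than these two readings show.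

Compound 3, `COc1cc(CC[C@H](C[C@H](O)CCc2ccc(O)c(O)c2)O[C@@H]2O[C@H](CO)[C@@H](O)[C@H](O)[C@H]2O)ccc1O`, is not yet measured. It differs from compound 2 by methyl in place of hydrogen on an oxygen on an aromatic ring, so one of the two 3,4-dihydroxyphenyl groups becomes a 4-hydroxy-3-methoxyphenyl while the other is kept.

With no measured step of this kind in the set, the expectation is a loss of potency that goes somewhat beyond the usual scatter, a step of a 2.0-fold higher number from compound 2 to compound 3 (0.30 log units; within the scatter). Compound 3 is therefore estimated at 6 ug/mL, with a range from 2.5 ug/mL to 15 ug/mL, and a real chance that only a limit is recorded.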

Compound 3, half-maximal inhibitory concentration: 4.5 ug/mL
For compound 3 the middle estimate is 1.3-fold (0.12 log units) above the measured one; measured number inside the range.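

Working notes on the series. In this assay, going by these compounds alone, the change from 3,4-dihydroxyphenyl to 4-hydroxy-3-methoxyphenyl gives the first measured reading for this position (a 1.5-fold higher number from compound 2 to compound 3 (0.18 log units; within the scatter)), so one free hydroxy at this place can carry methyl without a change that can be told from the scatter. The other single change in the set does register: hydroxy in place of hydrogen on an aromatic carbon gives a step beyond the scatter (an at least 2.2-fold lower number from compound 1 to compound 3 (0.34 log units; beyond the scatter)), and this holds with the methoxy group present. (The reading of compound 1 is a limit of the assay, and because of this the step has a lower bound only: the limit of > 10 ug/mL in this assay, at which 1 of the 3 values shown sits)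

As far as these compounds go, whether a longer chain such as ethoxy on that oxygen, or an amine in place of the hydroxy, would keep the reading remains open. So does the effect of methoxy on the second 3,4-dihydroxyphenyl group, and the methyl result rests on this one pair.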